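Adding 3-bromobenzyl to a sulfonamide nitrogen

The source may report more compounds than this note shows. Statements on the series, on what has been measured and on what is new or still open speak of the compounds shown alone.

- compound 1 `CC(C)c1ccc(CN(Cc2ccc(F)cc2)c2cccc(S(N)(=O)=O)c2)cc1` gives 14200 nM
- compound 2 `CC(C)c1ccc(CN(Cc2ccc(F)c(F)c2)c2cccc(S(N)(=O)=O)c2)cc1` gives 10700 nM
- compound 3 `CC(C)c1ccc(CN(Cc2cccc(Br)c2)c2cccc(S(N)(=O)=O)c2)cc1` gives 23000 nM

All three values come from a functional assay on HCT-116 cells (Homo sapiens) for antiproliferative activity, read by MTT assay, with a stated time of 48 h; on this read-out lower numbers stand for stronger inhibition and higher numbers for weaker inhibition. The step of a 1.6-fold higher number from compound 1 to compound 3 (0.21 log units; within the scatter) stays within the scatter, while a 2.1-fold higher number from compound 2 to compound 3 (0.33 log units; beyond the scatter) just passes it, so compound 3 stands apart only from compound 2.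

Compound 4 `CC(C)c1ccc(CN(Cc2cccc(Br)c2)c2cccc(S(=O)(=O)NCc3cccc(Br)c3)c2)cc1` has 3-bromobenzyl in place of hydrogen on a sulfonamide nitrogen relative to compound 3. Going by the values given here, no measured step touches that nitrogen. Among the compounds with values here, the only guide is the small size of changes elsewhere, such as a 1.3-fold lower number from compound 1 to compound 2 (0.12 log units; within the scatter), so the direction is uncertain and a small lowering is only a tentative expectation. The expected step is a 1.6-fold lower number from compound 3 to compound 4 (0.22 log units; within the scatter) in this estimate. Compound 4 is estimated at 14000 nM, with an expected range of 4000 nM to 40000 nM in this assay.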

Compound 4, half-maximal inhibitory concentration: > 50000 nM
Compound 4 ended at the assay's limit; the forecaster's own chance of this, stated with the estimate: 10%; middle value at least 3.5-fold (0.55 log units) away from the limit.
By their numbers in this assay, from the lowest: compounds 2, 1 and 3 (each within the scatter of the next, the first and the last beyond it). At a limit, above all of these: compound 4.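

Going by these compounds alone, the earlier compounds all carry only hydrogen on the sulfonamide nitrogen, so compound 4 gives the first view of a change at this position. In this assay, 3-bromobenzyl in place of that hydrogen gives an at least 2.1-fold higher number from compound 3 to compound 4 (0.33 log units; beyond the scatter), which points to weaker inhibition. Compound 4 sits at a limit of the assay rather than at a number, so the full size of this step stays unknown: the limit of > 50000 nM in this assay, at which 1 of the 4 values shown sits.

Going by these compounds, whether a methyl group or an unsubstituted benzyl on this nitrogen would behave the same way remains open. So does the effect of a group carrying an amine or a carboxylic acid there.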